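The compounds below may be only part of what the source reports. "The series", "measured", "known", "first", "only" and "open" are said of these compounds alone.

Measured in an ADME assay on microsomes from liver (Mus musculus) for metabolic stability; on this read-out higher numbers stand for fast clearance and lower numbers for slow clearance:

- compound 1 `CCOc1cc2[nH]c(Cc3nn(CC(=O)N4CCOCC4)c(=O)c4ccccc34)nc2cc1Cl`: 817 mL/min/kg
- compound 2 `O=C(Cc1nn(CC(=O)N2CCOCC2)c(=O)c2ccccc12)Nc1ccc(OC(F)(F)F)c(Cl)c1`: 11900 mL/min/kg
- compound 3 `COc1cc(OC)c(NC(=O)Cc2nn(CC(=O)O)c(=O)c3ccccc23)cc1Cl`: < 55 mL/min/kg

Compound 1, at 817 mL/min/kg, holds the lower of the two actual numbers. Compound 2 reads 11900 mL/min/kg, a gap well beyond the scatter. For compound 3, the reading of < 55 mL/min/kg is a limit of the assay and not a number.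

Compound 4 `CCOc1cc2[nH]c(Cc3nn(CC(=O)O)c(=O)c4ccccc34)nc2cc1Cl` keeps the core of compound 1 and differs in one place, with hydroxy in place of morpholin-4-yl on a carbonyl carbon. Cut one bond further out, this reads (morpholin-4-yl)carbonyl to carboxy. Among the compounds with values here, no measured pair shows this change alone, so the evidence is indirect.

Within the data shown here, the carboxy group that enters also stands on compound 3, the only compound reading at a limit, < 55 mL/min/kg. A clear fall in this assay, beyond the scatter, therefore seems likely. The expected change is a 12-fold lower number from compound 1 to compound 4 (1.07 log units; beyond the scatter). For compound 4, the estimated clearance is 70 mL/min/kg, with an expected range of 20 mL/min/kg to 300 mL/min/kg.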

Compound 4, clearance: < 51.7 mL/min/kg
Compound 4: only a limit was reported; the forecaster's own chance of this, stated with the estimate: 55%; middle value at least 1.3-fold (0.13 log units) from the limit.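

In this assay, exchanging morpholin-4-yl for hydroxy on a carbonyl carbon gives an at least 15-fold lower number from compound 1 to compound 4 (1.19 log units; beyond the scatter). Within the data shown here, this is the first direct view of this place, since no two earlier compounds differed in one place only, and it shows that a single change here can move the read-out by a large amount on the core of compound 1. The reading for compound 4 is a limit and not a number, so the step gives only the smallest possible size of the change: the limit of < 51.7 mL/min/kg in this assay, at which 1 of the 4 values shown sits.

As far as these compounds go, it remains open whether a smaller amide, such as a dimethylamino amide, or a methyl ester on the same carbonyl carbon would give a low number as well. From the compounds shown here alone, whether the same exchange gives a similar step on a different core also remains open.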